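From trifluoromethyl to hydroxy: one step in growth inhibition

A few compounds are considered here, and "the series" means these few. Any claim that something is new, unique, unknown or untested is made for them only; others in the source may bear on it.

Compound 1 `Oc1ccc(-c2ccc(-c3ccc(-c4nc5ccccc5[nH]4)cc3)cc2)cc1`: 100000 nM
Compound 2 `Cc1ccc2[nH]c(-c3ccc(-c4ccc(-c5ccc(F)cc5)cc4)cc3)nc2c1`: 100000 nM
Compound 3 `Cc1ccc2[nH]c(-c3ccc(-c4ccc(-c5ccc(C(F)(F)F)cc5)cc4)cc3)nc2c1`: 30600 nM

All three compounds were tested in a functional assay on COLO 205 cells (Homo sapiens) for inhibition, read by sulforhodamine B assay; a lower number here means a stronger inhibitor of growth, a higher number a weaker inhibitor of growth. Compound 3 has the lowest number of the three, and compound 1 and compound 2 share the same higher number, beyond the scatter from compound 3.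

The next compound is compound 4 `Cc1ccc2[nH]c(-c3ccc(-c4ccc(-c5ccc(O)cc5)cc4)cc3)nc2c1`, which keeps the structure of compound 3 except for one group: hydroxy in place of trifluoromethyl on an aromatic carbon. For the measured compounds named here, only one measured step changes a group at this place, and it is modest: a 3.3-fold lower number from compound 2 to compound 3 (0.51 log units; beyond the scatter), with trifluoromethyl in place of fluoro. Going by the values given here, no measured step shows what hydroxy does here. Compound 1 also carries the 4-hydroxyphenyl group and gives 100000 nM, but it is not otherwise the same as compound 4.

Taken together, these results point to losing trifluoromethyl moving the number up in this assay, by a modest amount like that of the measured step. The expected change is a 2.3-fold higher number from compound 3 to compound 4 (0.36 log units; beyond the scatter). For compound 4 the estimated value is 70000 nM, with an expected range from 28000 nM to 100000 nM.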

Compound 4, concentration for 50% growth inhibition: 100000 nM
Estimate against measurement, compound 4: 1.4-fold (0.15 log units) below; the range from low to high includes it.
By their numbers in this assay, from the lowest: compound 3; then compounds 1, 2 and 4 (each within the scatter of the next).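

In this assay, hydroxy now has its own measured step at this position on the outer ring, and it goes the same way as fluoro: replacing trifluoromethyl with hydroxy gives a higher number (a 3.3-fold higher number from compound 3 to compound 4 (0.51 log units; beyond the scatter)), while hydroxy and fluoro cannot be told apart (no change at the digits printed from compound 2 to compound 4 (within the scatter)). Among the three groups seen here, only trifluoromethyl stands out with a lower number, and even that number is still high in absolute terms, as compound 3 gives 30600 nM. With hydroxy in this position, adding a methyl to the shared core also leaves the number unmoved (no change at the digits printed from compound 1 to compound 4 (within the scatter)), and no supporting data are available to explain any of these results.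

As far as these compounds go, three groups are too few to show what trifluoromethyl's advantage depends on, so it remains open whether a chloro, a methoxy, an amine or a carboxylic acid at this position would match it or go lower. It is also open whether the methyl on the core matters when trifluoromethyl is present, since the compounds shown test that methyl only with hydroxy in place.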